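A few compounds are considered here, and "the series" means these few. Any claim that something is new, unique, unknown or untested is made for them only; others in the source may bear on it.

- compound 1 `CN(C)C(=O)c1cc2cnc(Nc3ccc(NC(=O)C4(C(=O)Nc5ccccc5F)CC4)cc3)nc2n1C1CCCC1` gives 97.8%
- compound 2 `COc1cccc(NC(=O)C2(C(=O)Nc3ccc(Nc4ncc5cc(C(=O)N(C)C)n(C6CCCC6)c5n4)cc3)CC2)c1` gives 93.5%

In a functional assay on T47D cells (Homo sapiens) for inhibition, read by CCK-8 assay, with a stated time of 72 h, tested at 10 uM (a higher number here means more inhibition of growth at the concentration tested, a lower number less inhibition of growth), compound 2 gives 93.5% and stands within the scatter of compound 1. Compound 3 `CN(C)C(=O)c1cc2cnc(Nc3ccc(NC(=O)C4(C(=O)Nc5cccc(Br)c5)CC4)cc3)nc2n1C1CCCC1` has not been measured. It carries bromo in place of methoxy on an aromatic carbon. Within the data shown here, one measured step bears on this aromatic group: a number 4.3 percentage points lower from compound 1 to compound 2 (within the scatter) came with 3-methoxyphenyl in place of 2-fluorophenyl and stayed within the scatter. No step beyond the scatter is therefore expected, and the estimated step is a number 0.5 percentage points higher from compound 2 to compound 3 (within the scatter) for this change. The expected value for compound 3 is 94% (estimated range 84% to 100%).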

Compound 3, percent growth inhibition at one concentration: 94.6%
The estimate for compound 3 lay 0.6 percentage points below the measured number; the range from low to high includes it.
By their numbers in this assay, from the lowest: compounds 2, 3 and 1 (each within the scatter of the next).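

In this assay, bromo in place of methoxy on the aromatic ring gives a number 1.1 percentage points higher from compound 2 to compound 3 (within the scatter), so at this place one bromine atom does as well as the two-atom methoxy with its hydrogen-bond acceptor. Set against the 2-fluorophenyl group, the 3-bromophenyl group gives a number 3.2 percentage points lower from compound 1 to compound 3 (within the scatter), which adds a third aromatic group that reads the same. Nothing available explains why this change leaves the number in place. Still open, from the compounds shown here alone, is whether this place on the ring also accepts an amine or a carboxylic acid. These three compounds lie too close together to be ranked.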